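The source may hold more compounds than are shown below. What is called first, only, known or untested is meant among the compounds shown, and "the series" means these compounds.

Measured so far in a functional assay on MDA-MB-435 cells (Homo sapiens) for cytotoxicity, read by sulforhodamine B assay, with a stated time of 48 h; on this read-out higher numbers stand for weaker inhibition of growth and lower numbers for stronger inhibition of growth:
compound 1 `Nc1nc(Cl)c2ncn(Cc3ccccc3CCl)c2n1`: 6030 nM
compound 2 `ClCc1ccccc1Cn1cnc2nc(Cl)nc(Cl)c21`: 16600 nM

Compound 1 holds the lowest of the two numbers in this assay. Compound 2 sits higher, and the gap lies beyond the usual scatter, so on these two values compound 1 is the stronger inhibitor of growth of the pair. Within the data shown here, no single-change step is available among the measured compounds, so the size of any one change has not yet been read directly.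

Compound 3 `ClCc1ccccc1Cn1cnc2c(Cl)ncnc21` is the next compound to go into this assay. It differs from compound 1 in one place: hydrogen in place of amino on an aromatic carbon. The change sits on an aromatic carbon between two ring nitrogen atoms of the core of compound 1; the chloro group and the fused ring stay where they are.

Among the measured compounds shown here, with no measured step in this assay to lean on, the expected step from compound 1 to compound 3 is a 1.8-fold higher number from compound 1 to compound 3 (0.26 log units; within the scatter), that is, a modest move toward weaker inhibition of growth, possibly within the scatter. Compound 3 is therefore expected to give about 11000 nM in this assay, with a range of 3500 nM to 35000 nM.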

Compound 3, concentration for 50% growth inhibition: 3020 nM
Beside the measured number, compound 3's estimate is 3.6-fold (0.56 log units) above it; measured number outside the range, below it.
By their numbers in this assay, from the lowest: compounds 3 and 1 (each within the scatter of the next); then compound 2.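

In this assay, hydrogen in place of amino on the aromatic carbon between two ring nitrogen atoms gives a 2.0-fold lower number from compound 1 to compound 3 (0.30 log units; within the scatter), so the two compounds cannot be told apart on this read-out. Among these compounds, this is the first direct reading of a single change, and it shows that the amino group, with its one hydrogen-bond donor and one hydrogen-bond acceptor, is not needed at this position to keep growth inhibition at the level of compound 1, while compound 3 still gives 3020 nM with only hydrogen there. No measured property or other supporting data accompany this step, so the result stands as an observation without an explanation.

With only amino and hydrogen shown on this carbon, one step says little about the position as a whole, and it remains open whether a methyl, a methoxy or a dimethylamino group there would move the number beyond the scatter. Also open, going by these compounds, is how much the chloro group on the core and the chloromethyl group contribute, which replacing them with a methoxy and a methyl group respectively-free of any other change would test directly.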